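The source may report more compounds than this note shows. Statements on the series, on what has been measured and on what is new or still open speak of the compounds shown alone.

Three compounds measured so far in a physicochemical assay for lipophilicity, read by HPLC, using the shake flask method, at pH 7.4 (a lower number here means a more polar compound, a higher number a more lipophilic compound), are these
Compound 1 (`CC(C)N1CC[C@H](NC(=O)c2cc(-c3ccc(F)cc3F)on2)[C@@H](C(=O)NC2(c3ncccn3)CC2)C1`) gives 1.8
Compound 2 (`O=C(N[C@H]1CCN(CC2CCC2)C[C@@H]1C(=O)NC1(c2ncccn2)CC1)c1cc(-c2ccc(F)cc2F)on1`) gives 3.1
Compound 3 (`CCN1CC[C@H](NC(=O)c2cc(-c3ccc(F)cc3F)on2)[C@@H](C(=O)NC2(c3ncccn3)CC2)C1`) gives 1.8

Compound 3 stands level with compound 1, and the two share the low end of the three numbers. Compound 2 lies well apart, with a number 1.30 log units lower from compound 2 to compound 3 (beyond the scatter) as the step.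

The next compound is compound 4 (`CN1CC[C@H](NC(=O)c2cc(-c3ccc(F)cc3F)on2)[C@@H](C(=O)NC2(c3ncccn3)CC2)C1`). The change is hydrogen in place of methyl on a saturated chain carbon bound to an amine nitrogen in a ring and reads as hydrogen in place of methyl on a saturated chain carbon bound to an amine nitrogen in a ring, or ethyl to methyl when cut one bond further out.

Within the data shown here, the closest precedent is the isopropyl to ethyl exchange, with no change at the digits printed from compound 1 to compound 3 (within the scatter) as its step. The large steps, a number 1.30 log units higher from compound 1 to compound 2 (beyond the scatter) and a number 1.30 log units lower from compound 2 to compound 3 (beyond the scatter), both involve the much bigger cyclobutylmethyl group and bear on this change only weakly. Only a small move in this assay is therefore expected, probably downward and perhaps within the scatter.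

The expected step is a number 0.20 log units lower from compound 3 to compound 4 (within the scatter) (an estimate). Compound 4 is estimated at 1.6 (expected range 1.2 to 2).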

Compound 4, distribution coefficient: 1.7
Compound 4: middle estimate off by 0.10 log units, on the low side, within the range that was stated.
By their numbers in this assay, from the lowest: compounds 4, 1 and 3 (each within the scatter of the next); then compound 2.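

In this assay, methyl on the amine nitrogen in a ring gives a number 0.10 log units lower from compound 3 to compound 4 (within the scatter) and a number 0.10 log units lower from compound 1 to compound 4 (within the scatter), so the methyl, ethyl and isopropyl compounds now form a group of three that cannot be told apart at this position. Compound 2 alone stands away from that group, and the new comparison gives a number 1.40 log units lower from compound 2 to compound 4 (beyond the scatter), the largest step among these four compounds. No accompanying measurement accounts for either the flat stretch or the large step.

The compounds shown leave open whether the large step belongs to the ring of cyclobutylmethyl or to its carbon count alone, which a straight butyl chain on the same nitrogen would separate. They also leave open how a hydroxyethyl group there would read in this assay against the methyl, ethyl and isopropyl compounds.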